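Swapping the trifluoromethyl ether of compound 3

The compounds below may be only part of what the source reports. "The series", "measured", "known", "first", "only" and "open" are said of these compounds alone.

In a functional assay for antagonist activity at Alpha-1A adrenergic receptor (Oryctolagus cuniculus) (on this read-out higher numbers stand for weaker binding and lower numbers for tighter binding), compound 3 `CN(C)C(=O)c1cccnc1NCCCN1CCN(c2ccccc2OC(F)(F)F)CC1` gives 3.16 nM, the second highest of the three numbers in hand. Compound 1 `COc1ccccc1N1CCN(CCCNc2ncccc2C(=O)N(C)C)CC1` gives 1.59 nM and compound 2 `CN(C)C(=O)c1cccnc1NCCCN1CCN(c2ccccc2)CC1` gives 6.31 nM. Of the measured steps, a 4.0-fold higher number from compound 1 to compound 2 (0.60 log units; beyond the scatter) is a modest one, while a 2.0-fold lower number from compound 2 to compound 3 (0.30 log units; within the scatter) stays within the scatter. Compound 4 `CN(C)C(=O)c1cccnc1NCCCN1CCN(c2ccccc2OCC2CC2)CC1` carries cyclopropylmethyl in place of trifluoromethyl on an oxygen on an aromatic ring. For the measured compounds named here, the closest precedent is a 2.0-fold higher number from compound 1 to compound 3 (0.30 log units; within the scatter), a change on the same oxygen that did not move the number beyond the scatter, and the whole set spans only a modest range, so compound 4 is expected to stay close to compound 3 in this assay. The estimate for compound 4 is 3.5 nM with a range from 1.2 nM to 11 nM, an expected step of a 1.1-fold higher number from compound 3 to compound 4 (0.04 log units; within the scatter).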

Compound 4, dissociation constant: 0.159 nM
Beside the measured number, compound 4's estimate is 22-fold (1.34 log units) above it, outside the stated range (below it).
By their numbers in this assay, from the lowest: compound 4; then compounds 1, 3 and 2 (each within the scatter of the next, the first and the last beyond it).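

Trifluoromethyl and cyclopropylmethyl both count 4 heavy atoms, yet on this oxygen in this assay the swap gives a 20-fold lower number from compound 3 to compound 4 (1.30 log units; beyond the scatter) whereas the earlier change on the same oxygen gave only a 2.0-fold higher number from compound 1 to compound 3 (0.30 log units; within the scatter) in this series. For the compounds shown here, the new group also stands apart from the other two compounds, with a 40-fold lower number from compound 2 to compound 4 (1.60 log units; beyond the scatter) for cyclopropylmethoxy in place of hydrogen and a 10-fold lower number from compound 1 to compound 4 (1.00 log units; beyond the scatter) for cyclopropyl in place of hydrogen on the methoxy carbon, so the group on this oxygen can move the number much further than the earlier compounds showed. Nothing available explains why this group has such an effect. Going by these compounds, whether a cyclobutyl group, a longer chain or an amine on the same oxygen would hold the number this low remains open.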